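The source may report more compounds than this note shows. Statements on the series, on what has been measured and on what is new or still open speak of the compounds shown alone.

Three compounds have been measured in an ADME assay on L02 cells (Homo sapiens) for cytotoxicity, read by MTT assay, with a stated time of 72 h; a higher number here means a weaker inhibitor, a lower number a stronger inhibitor:

Compound 1 `O=C(CCC(=O)OCCCCCCSc1ccc([N+](=O)[O-])c2nonc12)Nc1ccccc1`: 6490 nM
Compound 2 `Cc1ccccc1NC(=O)CCC(=O)OCCCCCCSc1ccc([N+](=O)[O-])c2nonc12`: 9490 nM
Compound 3 `COc1ccccc1NC(=O)CCC(=O)OCCCCCCSc1ccc([N+](=O)[O-])c2nonc12`: 4490 nM

All three share one core and differ only in a single group on the terminal benzene ring. Compound 1, the unsubstituted parent, has the second highest number of the three; the nearest is a 1.4-fold lower number from compound 1 to compound 3 (0.16 log units; within the scatter), and the furthest is a 1.5-fold higher number from compound 1 to compound 2 (0.17 log units; within the scatter). Compound 4 `COc1ccc(NC(=O)CCC(=O)OCCCCCCSc2ccc([N+](=O)[O-])c3nonc23)cc1` differs from compound 1 by methoxy in place of hydrogen on an aromatic carbon. Within the data shown here, the step that bears most directly on this is a 1.4-fold lower number from compound 1 to compound 3 (0.16 log units; within the scatter), which stayed within the scatter; the only step beyond it was a 2.1-fold lower number from compound 2 to compound 3 (0.33 log units; beyond the scatter), a modest one. Compound 4 is therefore expected to show a 1.2-fold lower number from compound 1 to compound 4 (0.07 log units; within the scatter), nothing beyond the scatter. Compound 4 is estimated at 5500 nM, between 2500 nM and 12000 nM.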

Compound 4, half-maximal inhibitory concentration: 8170 nM
For compound 4 the middle estimate is 1.5-fold (0.17 log units) below the measured one; the range from low to high includes it.
By their numbers in this assay, from the lowest: compounds 3, 1, 4 and 2 (each within the scatter of the next, the first and the last beyond it).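

In this assay, methoxy on the aromatic carbon para to a large group leaves the number within the scatter of the unsubstituted parent (a 1.3-fold higher number from compound 1 to compound 4 (0.10 log units; within the scatter)). The other two comparisons also stay within the scatter (a 1.8-fold higher number from compound 3 to compound 4 (0.26 log units; within the scatter); a 1.2-fold lower number from compound 2 to compound 4 (0.07 log units; within the scatter)), so swapping 2-methoxyphenyl for 4-methoxyphenyl makes no readable difference here, and neither does swapping 2-methylphenyl for 4-methoxyphenyl. No evidence at hand explains these numbers. Going by these compounds, whether an amine or a carboxylic acid on this ring would shift the number beyond the scatter remains open.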